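The compounds below may be only part of what the source reports. "The series", "measured", "known", "first", "only" and "open" are said of these compounds alone.

The series shares one core, carried by compound 1 `CN1C(=O)C(CC2CC2)N(C)c2nc(Nc3ccc(S(N)(=O)=O)cc3)ncc21`, compound 2 `CN1C(=O)C(c2cccc(C(F)(F)F)c2)N(C)c2nc(Nc3ccc(S(N)(=O)=O)cc3)ncc21` and compound 3 `CN1C(=O)C(c2ccccc2F)N(C)c2nc(Nc3ccc(S(N)(=O)=O)cc3)ncc21`. In an assay on Sf9 cells for inhibition of serine/threonine-protein kinase 4 (Homo sapiens), read by luminescence and ADP-Glo, with a stated time of 1 h, in the presence of a further agent that is not named here (on this read-out higher numbers stand for weaker inhibition and lower numbers for stronger inhibition), compound 1 gives 211 nM, compound 2 gives 2710 nM and compound 3 gives 75 nM. Compound 3 stands lowest of the three: the step of a 2.8-fold lower number from compound 1 to compound 3 (0.45 log units; beyond the scatter) is modest, the step of a 36-fold lower number from compound 2 to compound 3 (1.56 log units; beyond the scatter) is large, and the step of a 13-fold higher number from compound 1 to compound 2 (1.11 log units; beyond the scatter) runs the other way. Compound 4 `COc1ccccc1C1C(=O)N(C)c2cnc(Nc3ccc(S(N)(=O)=O)cc3)nc2N1C` differs from compound 3 by methoxy in place of fluoro on an aromatic carbon. Going by the values given here, no measured step alters only the group on this aromatic ring: the change a 36-fold lower number from compound 2 to compound 3 (1.56 log units; beyond the scatter) moved both the kind and the place of the substituent, and the other two steps exchanged the whole aryl group for cyclopropylmethyl. Those steps show that what sits on the saturated ring carbon matters greatly in this assay, yet they give no direct guide for methoxy against fluoro. A small step in either direction, not clearly beyond the scatter, is therefore expected for compound 4, shown as a 1.6-fold higher number from compound 3 to compound 4 (0.20 log units; within the scatter). Compound 4 is thus estimated at 120 nM, in the range 40 nM to 400 nM.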

Compound 4, half-maximal inhibitory concentration: 251 nM
Beside the measured number, compound 4's estimate is 2.1-fold (0.32 log units) below it; low and high end bracket the measured number.
By their numbers in this assay, from the lowest: compound 3; then compounds 1 and 4 (each within the scatter of the next); then compound 2.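

Going by these compounds alone, exchanging fluoro for methoxy, ortho to a large group, is the first change that leaves the rest of the aryl group in place, and in this assay it gives a 3.3-fold higher number from compound 3 to compound 4 (0.52 log units; beyond the scatter), so this single substituent can shift the result by itself. The 2-fluorophenyl group stood apart from cyclopropylmethyl, but 2-methoxyphenyl does not, with a 1.2-fold higher number from compound 1 to compound 4 (0.08 log units; within the scatter), while an 11-fold lower number from compound 2 to compound 4 (1.03 log units; beyond the scatter) shows that 2-methoxyphenyl still stands far from 3-(trifluoromethyl)phenyl. No measurement is available to explain the difference between methoxy and fluoro.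

The compounds shown leave open how a chloro or hydroxy group would compare at this same place. They also do not separate the kind of substituent from its place, since methoxy, fluoro and trifluoromethyl are never compared at each position on the ring.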